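Sulfur-linked benzamides: the group on sulfur

The compounds below may be only part of what the source reports. "The series", "measured", "known", "first", "only" and "open" are said of these compounds alone.

Measured compounds:
compound 1 `Cc1ccc(SCc2ccc(C(=O)Nc3ccccc3N)cc2)cc1`: 74.8%
compound 2 `Cc1cc(C)cc(SCc2ccc(C(=O)Nc3ccccc3N)cc2)c1`: 3.22%

In a functional assay on HCT-116 cells (Homo sapiens) for inhibition, read by CCK-8 assay, with a stated time of 72 h, tested at 2 uM (a lower number here means less inhibition of growth, a higher number more inhibition of growth at the concentration tested), compound 1 gives 74.8%. Compound 2 gives 3.22%, the lower of the two numbers in this assay. Going by the values given here, the only measured step, a number 71.6 percentage points lower from compound 1 to compound 2 (beyond the scatter), concerns the group on the sulfur and was large.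

Compound 3 `Nc1ccccc1NC(=O)c1ccc(CSCCc2ccccc2)cc1` differs from compound 2 by phenethyl in place of 3,5-dimethylphenyl on a sulfur. Among the compounds with values here, this change sits at the same sulfur as the measured step, so a number 71.6 percentage points lower from compound 1 to compound 2 (beyond the scatter) is the one step that bears on it, and it shows that the group on sulfur can move the number by a large amount. Within the data shown here, no measured pair contains phenethyl, so the direction is not fixed by the data; since compound 2 stands at the bottom of the two numbers, a move, if any, is more likely upward than downward.

Compound 3 is expected to give 30%, with a range of 3% to 65%. The estimated step is a number 26.8 percentage points higher from compound 2 to compound 3 (beyond the scatter), an expectation rather than a measurement.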

Compound 3, percent growth inhibition at one concentration: 30.5%
The estimate for compound 3 lay 0.5 percentage points below the measured number; the measured number falls inside the stated range.
By their numbers in this assay, from the lowest: compound 2; then compound 3; then compound 1.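

With this assay as the read-out, phenethyl and 3,5-dimethylphenyl carry the same atoms joined differently, and this change alone gives a number 27.3 percentage points higher from compound 2 to compound 3 (beyond the scatter) in a direction the earlier pair did not show. The aromatic ring therefore need not be attached directly to the sulfur for growth inhibition to remain at this concentration, although replacing 4-methylphenyl with phenethyl gives a number 44.3 percentage points lower from compound 1 to compound 3 (beyond the scatter) and leaves compound 1 highest of the three. No available measurement accounts for this order.

Open, on these data alone, is whether benzyl, a longer chain ending in a phenyl ring, or a chain ending in an amine on the sulfur would fall nearer compound 1 or compound 2. Also open, as far as these compounds go, is whether unsubstituted phenyl on the sulfur would match the number of compound 1.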